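This account rests on a few compounds, and the source may have more. Where it says the series, first, only, none or still open, it means among the compounds named here.

Measured so far in an assay on Prostate gland (Oryctolagus cuniculus) for inhibition of Adrenergic receptor alpha-1 (Homo sapiens); on this read-out higher numbers stand for weaker binding and lower numbers for tighter binding:
Compound 1 `COc1ccccc1N1CCN(CCC(Oc2ccc(C(=O)Nc3ccccc3OCCCC(=O)O)cc2)c2cccc(C)c2)CC1` gives 251 nM.
Compound 2 `COc1ccccc1N1CCN(CCC(Oc2ccc(C(=O)Nc3ccccc3OCCCC(=O)O)cc2)c2ccc(C)cc2)CC1` gives 15.9 nM.

Among the measured compounds shown here, compound 2 stands lowest of these two numbers, and the single step, a 16-fold lower number from compound 1 to compound 2 (1.20 log units; beyond the scatter), is large and beyond the scatter. Compound 3 `COc1ccc(C(CCN2CCN(c3ccccc3OC)CC2)Oc2ccc(C(=O)Nc3ccccc3OCCCC(=O)O)cc2)cc1` differs from compound 2 by methoxy in place of methyl on an aromatic carbon. For the measured compounds named here, no measured step exchanges methyl for methoxy, so the earlier step only shows that a change on this ring can shift the number strongly. Compound 3 is therefore expected at 22 nM, between 5 nM and 90 nM, an estimated step of a 1.4-fold higher number from compound 2 to compound 3 (0.14 log units; within the scatter).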

Compound 3, dissociation constant: 200 nM
Estimate against measurement, compound 3: 9.1-fold (0.96 log units) below; measured number outside the range, above it.
By their numbers in this assay, from the lowest: compound 2; then compounds 3 and 1 (each within the scatter of the next).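

Exchanging methyl for methoxy at this position, on the ring carbon para to a large group, gives a 13-fold higher number from compound 2 to compound 3 (1.10 log units; beyond the scatter), so a single added oxygen can decide the outcome here. The 4-methoxyphenyl and 3-methylphenyl groups cannot be told apart, with a 1.3-fold lower number from compound 1 to compound 3 (0.10 log units; within the scatter), so the low number of compound 2 belongs to 4-methylphenyl alone among these three compounds. Nothing available explains this difference. Still open, from the compounds shown here alone, is how an ethyl, a chlorine or a hydroxyl at this position would compare, and whether the same order holds with a shorter acid chain.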